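The source may hold more compounds than are shown below. What is called first, only, known or untested is meant among the compounds shown, and "the series" means these compounds.

Compound 1 `COc1cc2nc(Nc3ccc(C#N)cc3)nc(Nc3c(C)cc(/C=C/C#N)cc3C)c2cc1OC`: 10200 nM
Compound 2 `COc1cc2nc(SCC(=O)Nc3ccc(C(F)(F)F)cc3)nc(Nc3c(C)cc(/C=C/C#N)cc3C)c2cc1OC`: > 211000 nM (a limit)
Compound 3 `COc1cc2nc(SCC(=O)Nc3cccc(S(N)(=O)=O)c3)nc(Nc3c(Cl)cc(/C=C/C#N)cc3Cl)c2cc1OC`: > 194000 nM (a limit)

These values come from an ADME assay on MT4 cells (Homo sapiens) for cytotoxicity, read by MTT assay, with a stated time of 5 days; on this read-out higher numbers stand for lower toxicity in this test and lower numbers for higher toxicity in this test. Only compound 1 gives a true number, 10200 nM. Compound 2 is reported as > 211000 nM, which is a limit of the assay and not a number. Going by these compounds, compound 3 likewise stands at a limit, > 194000 nM, so its exact position is unknown.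

Compound 4 `COc1cc2nc(SCC(=O)Nc3ccc(S(N)(=O)=O)cc3)nc(Nc3c(Cl)cc(/C=C/C#N)cc3Cl)c2cc1OC` has the same atoms as compound 3, joined differently, with 4-sulfamoylphenyl in place of 3-sulfamoylphenyl on an amide-type nitrogen. For the measured compounds named here, no measured step shows what such a change does, so no change beyond the scatter is expected in this assay. The expected step runs a number no higher from compound 3 to compound 4 (the limit leaves the size open). The estimate for compound 4 is 194000 nM, with an expected range of 60000 nM to 220000 nM.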

Compound 4, half-maximal cytotoxic concentration: 116000 nM
For compound 4 the middle estimate is 1.7-fold (0.22 log units) above the measured one; low and high end bracket the measured number.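

In this assay, 4-sulfamoylphenyl in place of 3-sulfamoylphenyl on an amide-type nitrogen gives an at least 1.6-fold lower number from compound 3 to compound 4 (0.22 log units; that floor lies within the scatter). For the compounds shown here, compound 4 thereby supplies a true number for this pair of sulfamoylphenyl isomers, and the first true number among the compounds carrying the amide-type side chain. The full size of the step stays unknown because compound 3 stands at a limit: the limit of > 194000 nM in this assay, at which 1 of the 4 values shown sits.

Still open, going by these compounds, is how a carboxylic acid or an amine in place of the sulfamoyl group would read in this assay.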